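Aryl Ketone to Cyano on the Shared Core

The source may report more compounds than this note shows. Statements on the series, on what has been measured and on what is new or still open speak of the compounds shown alone.

Compound 1 `CC1(C)C=C(n2ccccc2=O)c2cc(C(=O)c3ccc(O)cc3)ccc2O1` gives 6.65 in a functional assay (aorta) with Rattus norvegicus as the target; a higher number here means a more potent compound, by a factor of ten per unit of this negative logarithm, a lower number a less potent compound. Going by the values given here, compound 2 `Cc1ccccc1C(=O)c1ccc2c(c1)C(n1ccccc1=O)=CC(C)(C)O2` gives 6.83 in this assay; its only neighbour in the set is compound 1, and the step is a number 0.18 log units higher from compound 1 to compound 2 (within the scatter). Compound 3 `CC1(C)C=C(n2ccccc2=O)c2cc(C#N)ccc2O1` differs from compound 2 by cyano in place of (2-methylphenyl)carbonyl on an aromatic carbon. Among the compounds with values here, the one measured step swaps one aryl group for another on the carbonyl carbon and offers nothing on removing the (2-methylphenyl)carbonyl entirely; no measured compound carries a cyano here. Compound 3 is expected near 6.6, with a wide range from 5.7 to 7.5. The expected step is a number 0.23 log units lower from compound 2 to compound 3 (within the scatter), not clearly beyond the scatter.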

Compound 3, logarithm of the reciprocal of the active concentration, log(1/C): 7.67
The estimate for compound 3 lay 1.07 log units below the measured number; the measured number lies above the stated range.
By their numbers in this assay, from the lowest: compounds 1 and 2 (each within the scatter of the next); then compound 3.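

At this aromatic carbon, meta to a fused ring and para to a fused ring, the aryl ketone is not required for potency in this assay, since cyano raises the number in both available comparisons (a number 0.84 log units higher from compound 2 to compound 3 (beyond the scatter); a number 1.02 log units higher from compound 1 to compound 3 (beyond the scatter)). The earlier step only exchanged one aryl group for another on the carbonyl carbon and stayed within the scatter, whereas replacing the whole aryl carbonyl unit moves the number beyond it. No measured evidence bears on the reason for this gain.
Going by these compounds, whether the gain belongs to cyano itself or to the loss of the aryl carbonyl remains open. Also open, on these data alone, is how an amine, a carboxylic acid or a methyl ester would fare at this carbon.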